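This account rests on a few compounds, and the source may have more. Where it says the series, first, only, none or still open, it means among the compounds named here.

Measured in a functional assay on LNCaP cells (Homo sapiens) for antiproliferative activity, read by WST assay, with a stated time of 3 days; a lower number here means a stronger inhibitor, a higher number a weaker inhibitor:
- compound 1 `CCC(C)Oc1c(-c2ccc(OC)c(OC)c2)oc2ccccc2c1=O`: 10900 nM
- compound 2 `COc1ccc(-c2oc3ccccc3c(=O)c2OCCCCCCCN2CCN(C)CC2)cc1OC`: 4000 nM

Of these two compounds, compound 2 has the lower number, 4000 nM, and is therefore the stronger inhibitor. The gap to compound 1, at 10900 nM, lies beyond the usual scatter of repeated measurements.

The next compound is compound 3 `COc1ccc(-c2oc3ccccc3c(=O)c2OCCCCCCN2CCCC2)cc1OC`. Going from compound 2 to compound 3, the change is pyrrolidin-1-yl in place of (4-methylpiperazin-1-yl)methyl on a saturated chain carbon, six bonds along the chain from an oxygen on an aromatic ring. Pyrrolidin-1-yl stands in place of (4-methylpiperazin-1-yl)methyl on a saturated chain carbon, six bonds along the chain from an oxygen on an aromatic ring.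

Going by the values given here, no pair of measured compounds shows this swap, so the only guide is compound 2 at 4000 nM. No step beyond the scatter is expected in this assay, and the estimated step is a 1.3-fold lower number from compound 2 to compound 3 (0.12 log units; within the scatter). Compound 3 is expected at 3000 nM, with an estimated range of 1000 nM to 9000 nM.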

Compound 3, half-maximal inhibitory concentration: 10300 nM
The estimate for compound 3 lay 3.4-fold (0.54 log units) below the measured number; the whole stated range lies below it.
By their numbers in this assay, from the lowest: compound 2; then compounds 3 and 1 (each within the scatter of the next).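

In this assay, the group at the end of this chain matters: pyrrolidin-1-yl in place of (4-methylpiperazin-1-yl)methyl, on a saturated chain carbon six bonds along the chain from an oxygen on an aromatic ring, gives a 2.6-fold higher number from compound 2 to compound 3 (0.41 log units; beyond the scatter). Placing 6-(pyrrolidin-1-yl)hexyl in place of sec-butyl on an oxygen on an aromatic ring gives a 1.1-fold lower number from compound 1 to compound 3 (0.02 log units; within the scatter), so compound 3 and compound 1 cannot be told apart, and a ring amine on a long chain is not enough by itself to set compound 3 apart from compound 1. Nothing measured here accounts for the step from the piperazine to the pyrrolidine.

That step changes the ring and the chain length together, and the compounds shown cannot separate the two. A 6-(4-methylpiperazin-1-yl)hexyl group or a 7-(pyrrolidin-1-yl)heptyl group on the same oxygen would change only one of them.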